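Swapping a butoxyphenyl for pyridinyl on a pyrazoline core

This account rests on a few compounds, and the source may have more. Where it says the series, first, only, none or still open, it means among the compounds named here.

Measured compounds:
- compound 1, `CN1CCN(NC(=O)C2=NN(c3ccc(Cl)cc3Cl)C(c3ccc(Cl)cc3)C2)CC1`, 22.6%
- compound 2, `O=C(NN1CCOCC1)C1=NN(c2ccc(Cl)cc2)C(c2ccc(Cl)cc2)C1`, 8.1%
- compound 3, `CCCCOc1ccc(C2CC(C(=O)NN3CCOCC3)=NN2c2ccc(Cl)cc2Cl)cc1`, 18.1%

All three were tested in a functional assay on the whole organism (strain Zucker) for inhibition, with Rattus norvegicus as the target, with a stated time of 4 h, at a dose of 10 mg/kg by the oral route; a lower number here means less inhibition, a higher number more inhibition at the dose given (going by the name of the read-out). Compound 3 gives 18.1% in this assay. Its number lies between those of the other two, but the gap to compound 1 and the gap to compound 2 are both within the usual scatter of repeated measurements, so the three compounds cannot be told apart on these numbers alone. For the measured compounds named here, no pair of the measured compounds differs in only one place, so no single structural change can be tied to a change in the read-out.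

Compound 4, `O=C(NN1CCOCC1)C1=NN(c2ccc(Cl)cc2Cl)C(c2cccnc2)C1`, has not yet been measured. Relative to compound 3 it carries pyridin-3-yl in place of 4-butoxyphenyl on a saturated ring carbon. The change sits on the saturated ring carbon of the shared core, away from the 2,4-dichlorophenyl group and the (morpholin-4-yl)carbamoyl group that compound 3 and compound 4 have in common.

Going by the values given here, nothing among the measured compounds shows what this replacement does. The step from compound 3 to compound 4 is therefore expected to be small, most likely downward, and not clearly beyond the scatter: a number 4.1 percentage points lower from compound 3 to compound 4 (within the scatter). Compound 4 is expected to give about 14% in this assay, with a range from 2% to 28%.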

Compound 4, a percentage reported as inhibition, in the whole organism at one dose (the size of the read-out at that dose, not a potency): 4%
Beside the measured number, compound 4's estimate is 10 percentage points above it; the range from low to high includes it.
By their numbers in this assay, from the lowest: compounds 4, 2, 3 and 1 (each within the scatter of the next, the first and the last beyond it).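

In this assay, the saturated ring carbon of the shared core is shown to matter: pyridin-3-yl in place of 4-butoxyphenyl gives a number 14.1 percentage points lower from compound 3 to compound 4 (beyond the scatter). For the compounds shown here, this is the first comparison in the set that differs in only one place, so the drop can be tied to this replacement, with the 2,4-dichlorophenyl group and the (morpholin-4-yl)carbamoyl group held the same. No measurement shown here explains why the number falls.

The replacement changes several things at once: the butoxy chain is lost, the group falls from 11 heavy atoms to 6, and a ring carbon gives way to a ring nitrogen, and a single step cannot separate these. A plain phenyl or a 4-methoxyphenyl group on the same carbon would help to show whether the loss follows the chain or the ring nitrogen, while a pyridin-3-yl ring carrying a butoxy chain would test the ring nitrogen with the chain kept in place.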